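Lengthening the chain to the 2-nitro-1H-imidazol-1-yl group

The source may hold more compounds than are shown below. What is called first, only, known or untested is meant among the compounds shown, and "the series" means these compounds.

compound 1 `COc1cc2ncnc(Nc3ccc(F)c(Cl)c3)c2cc1OCCCCn1ccnc1[N+](=O)[O-]`: 1620 nM
compound 2 `COc1cc2ncnc(Nc3ccc(OCc4cccc(F)c4)c(Cl)c3)c2cc1OCCCn1ccnc1[N+](=O)[O-]`: 20000 nM

In a functional assay on HT-29 cells (Homo sapiens) for cytotoxicity, read by sulforhodamine B assay, with a stated time of 72 h (a lower number here means a stronger inhibitor, a higher number a weaker inhibitor), compound 1 gives 1620 nM and compound 2 gives 20000 nM, the highest of the two numbers, with a gap to compound 1 that lies beyond the scatter. Compound 3 `COc1cc2ncnc(Nc3ccc(OCc4cccc(F)c4)c(Cl)c3)c2cc1OCCCCn1ccnc1[N+](=O)[O-]` differs from compound 2 by (2-nitro-1H-imidazol-1-yl)methyl in place of 2-nitro-1H-imidazol-1-yl on a saturated chain carbon, three bonds along the chain from an oxygen on an aromatic ring. For the measured compounds named here, no measured pair shows this change on its own, so its size is uncertain; a step within the scatter, in either direction, is expected. Compound 3 is therefore estimated at 12000 nM, between 4000 nM and 40000 nM. That estimate means an expected step of a 1.7-fold lower number from compound 2 to compound 3 (0.22 log units; within the scatter).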

Compound 3, half-maximal inhibitory concentration: 2070 nM
Beside the measured number, compound 3's estimate is 5.8-fold (0.76 log units) above it; measured number below the stated range.
By their numbers in this assay, from the lowest: compounds 1 and 3 (each within the scatter of the next); then compound 2.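

Lengthening the chain from 3-(2-nitro-1H-imidazol-1-yl)propyl to 4-(2-nitro-1H-imidazol-1-yl)butyl gives, in this assay, a 9.7-fold lower number from compound 2 to compound 3 (0.99 log units; beyond the scatter) and so shows that this position responds to a single added chain carbon. With the butyl chain held, (3-fluorobenzyl)oxy in place of fluoro on an aromatic carbon gives a 1.3-fold higher number from compound 1 to compound 3 (0.11 log units; within the scatter) and so stays within the scatter. Nothing available here accounts for either result. From the compounds shown here alone, whether a longer chain would go further remains open. So does whether an amine could replace the 2-nitro-1H-imidazol-1-yl group, and whether the chain step also holds with fluoro on the aromatic carbon.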